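Taking the Acetyl Group Off Compound 3

This account rests on a few compounds, and the source may have more. Where it says the series, first, only, none or still open, it means among the compounds named here.

Three related compounds have been tested so far in a functional assay on HaCaT cells (Homo sapiens), read by MTT assay, with a stated time of 48 h (a higher number here means a weaker inhibitor, a lower number a stronger inhibitor), and none of them gives an exact number. In this assay compound 1 `CCc1noc(-c2cc3c(OC)ccc(OC)c3s2)n1` gives > 30000 nM as a limit of the assay and not a number. Compound 2 `CCc1noc(-c2ccc(C(=O)c3ccccc3)s2)n1` gives > 30000 nM as a limit too. Compound 3 `CCc1noc(-c2ccc(C(C)=O)cc2)n1` gives > 30000 nM as a limit as well. The whole record therefore comes down to the limit of > 30000 nM in this assay, at which 3 of the 3 values shown sit, and compound 3 stands level with the other two, with no exact number of its own.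

Compound 4 `CCc1noc(-c2ccccc2)n1` has not yet been measured. It differs from compound 3 by a single change: hydrogen in place of acetyl on an aromatic carbon in which hydrogen takes the place of acetyl on an aromatic carbon. Among the compounds with values here, no measured pair here differs in just one place, so there is no direct guide to the size of this step. The expectation rests on compound 3, whose > 30000 nM is a limit. No step beyond the scatter is expected in this assay in either direction, and another limit is the most likely report. The estimated step that the limit leaves unreadable from compound 3 to compound 4 stays within the usual scatter. For compound 4 the estimated value is 35000 nM with an expected range from 15000 nM as lower end to 80000 nM as upper end.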

Compound 4, half-maximal inhibitory concentration: > 30000 nM
Compound 4: only a limit was reported; the forecaster's own chance of this, stated with the estimate: 85%; the middle value is on the limit's open side.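

Compound 3 and compound 4 both stand only as limits in this assay, so the size of the step on swapping acetyl for hydrogen cannot be read: the limit of > 30000 nM in this assay, at which 4 of the 4 values shown sit.

The compounds shown leave open whether this swap changes activity at all, and which compound of this kind, if any, would give an exact number in this assay.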